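Shifting the Hydroxyl on the Side Ring of Compound 1

The source may report more compounds than this note shows. Statements on the series, on what has been measured and on what is new or still open speak of the compounds shown alone.

Compound 1 `O=C(N/N=C/c1ccccc1O)c1ccc(-c2ccc(F)cc2)o1` was tested in a functional assay on Bel-7402 cells (Homo sapiens) for inhibition, read by sulforhodamine B assay, with a stated time of 48 h, tested at 10 uM (on this read-out lower numbers stand for less inhibition of growth and higher numbers for more inhibition of growth at the one concentration tested), where compound 1 gives 40%. Going by the values given here, this is the highest of the three numbers measured so far. Compound 2 `Cc1cccc(/C=N/NC(=O)c2ccc(-c3ccccc3[N+](=O)[O-])o2)c1` gives 6.66% in this assay, and compound 3 `COc1ccccc1C(=O)N/N=C/c1ccc(-c2ccc(F)cc2F)o1` gives 1.69%; both lie beyond the usual scatter below compound 1. Compounds 2 and 3 differ from compound 1 in more than one place, so their numbers say only what they show on their own and not what any single change does.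

Compound 4 `O=C(N/N=C/c1ccc(O)cc1)c1ccc(-c2ccc(F)cc2)o1` has not yet been measured. It differs from compound 1 in one place only: 4-hydroxyphenyl in place of 2-hydroxyphenyl on a carbon with a double bond to nitrogen. The two compounds share every atom; only the hydroxyl has moved within the ring. Among the compounds with values here, no pair of measured compounds differs by such a shift, so nothing in the data sets the size of this step. The expectation is therefore cautious: a step that stays within the usual scatter, or at most a modest decrease, is expected, a number 10 percentage points lower from compound 1 to compound 4 (within the scatter). Compound 4 is expected to give about 30% in this assay, with a range from 5% to 55%.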

Compound 4, percent growth inhibition at one concentration: 10.6%
Compound 4: middle estimate off by 19.4 percentage points, on the high side; measured number inside the range.
By their numbers in this assay, from the lowest: compounds 3, 2 and 4 (each within the scatter of the next); then compound 1.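

Replacing 2-hydroxyphenyl with 4-hydroxyphenyl on a carbon with a double bond to nitrogen gives a number 29.4 percentage points lower from compound 1 to compound 4 (beyond the scatter) in this assay. Going by these compounds alone, the earlier compounds differed from compound 1 in more than one place, so this is the first single change that can be read, and it shows that the location of the hydroxyl on this ring alone can alter growth inhibition at the one concentration tested, even though the atoms stay the same. No available measurement explains this step.

As far as these compounds go, it remains open whether an amine or a carboxylic acid in place of the hydroxyl on this ring would keep the number of compound 1 or lower it. From the compounds shown here alone, it is also open whether the same shift of the hydroxyl would give a step of similar size on a different core.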